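The source may report more compounds than this note shows. Statements on the series, on what has been measured and on what is new or still open speak of the compounds shown alone.

Of the compounds shown here, three sharing a trimethoxyphenyl-bearing core have been tested in a functional assay on HCT-116 cells (Homo sapiens) for inhibition, read by MTT assay, with a stated time of 48 h; on this read-out lower numbers stand for stronger inhibition and higher numbers for weaker inhibition. Compound 1 `COc1cc(NCc2cccc(O)c2)cc(OC)c1OC` gives 67700 nM. Compound 2 `C/C=C/C(=O)N(Cc1cccc(O)c1)c1cc(OC)c(OC)c(OC)c1` gives 6700 nM, and compound 3 `C/C=C/C(=O)N(Cc1ccc(OC)cc1)c1cc(OC)c(OC)c(OC)c1` gives 500 nM, the lowest of the three numbers. Between compound 2 and compound 1 the change is hydrogen in place of (prop-1-en-1-yl)carbonyl on a nitrogen on an aromatic ring, and the step is a 10-fold higher number from compound 2 to compound 1 (1.00 log units; beyond the scatter). The cores of compound 2 and compound 3 differ by 4-methoxyphenyl in place of 3-hydroxyphenyl on a saturated chain carbon bound to an amide-type nitrogen, and the step is a 13-fold lower number from compound 2 to compound 3 (1.13 log units; beyond the scatter).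

Compound 4 `COc1ccc(CNc2cc(OC)c(OC)c(OC)c2)cc1` has not yet been measured in this assay. It differs from compound 3 by hydrogen in place of (prop-1-en-1-yl)carbonyl on a nitrogen on an aromatic ring, which is the same change as that between compound 2 and compound 1, made at a place described in the same words. The step from compound 3 to compound 4 is therefore expected to resemble the earlier one, so that compound 4 would show a 10-fold higher number from compound 3 to compound 4 (1.00 log units; beyond the scatter) in this assay. This rests on the step of a 10-fold higher number from compound 2 to compound 1 (1.00 log units; beyond the scatter) and on compound 3, which gives 500 nM. Compound 4 is thus estimated at 5000 nM, with a range from 1500 nM to 20000 nM.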

Compound 4, half-maximal inhibitory concentration: 18400 nM
Beside the measured number, compound 4's estimate is 3.7-fold (0.57 log units) below it, within the range that was stated.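

Putting hydrogen in place of (prop-1-en-1-yl)carbonyl on the nitrogen raises the number again in this assay, with a 37-fold higher number from compound 3 to compound 4 (1.57 log units; beyond the scatter). The direction of this change therefore carries over from one core to the other in these two cases, but its size does not: the same change on two cores in this assay, a 10-fold higher number (1.00 log units; beyond the scatter) from compound 2 to compound 1 and a 37-fold higher number (1.57 log units; beyond the scatter) from compound 3 to compound 4, 3.6-fold (0.56 log units) apart, beyond the scatter of two such steps. Two cores are a small sample, and they neither give a general size for this step nor show what makes it larger on one core than on the other.

As far as these compounds go, it remains open whether a smaller acetyl group, a saturated butanoyl group or a longer chain on the nitrogen would give numbers like those of compound 2 and compound 3, which would show how much of the (prop-1-en-1-yl)carbonyl group matters. From the compounds shown here alone, it is also open whether the step would keep its direction on a core carrying an amine or a carboxylic acid in place of the methoxy group of the 4-methoxyphenyl ring in compound 3.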